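The source may report more compounds than this note shows. Statements on the series, on what has been measured and on what is new or still open speak of the compounds shown alone.

Of the compounds shown here, two have been measured so far in an assay on isolated protein for inhibition of NAD-dependent protein deacylase sirtuin-6 (Homo sapiens), read by fluorescence, tested at 200 uM; a higher number here means more inhibition at the concentration tested (going by the name of the read-out), a lower number less inhibition. Compound 1, `O=C(Nc1ccc(O)c(C(=O)O)c1)c1cccc(N2C(=O)CCS2(=O)=O)c1`, and compound 2, `O=C(Nc1ccc(O)c(C(=O)O)c1)c1ccc(NC(=O)C2CC2)cc1`, share a core and differ in the group attached to the far aromatic ring. In this assay compound 1 gives 54%, while compound 2 gives 50%. Compound 1 thus holds the higher of the two numbers, but the gap to compound 2 lies within the scatter of repeated measurements, so the two cannot be ranked against each other on this evidence.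

The next compound, compound 3, `O=C(O)c1cccc(NC(=O)c2cccc(N3C(=O)CCS3(=O)=O)c2)c1`, keeps the whole of compound 1 except for one change: hydrogen in place of hydroxy on an aromatic carbon. Among the compounds with values here, no measured pair in the set isolates this kind of change, so the size of its effect is unknown. Because compound 1 sits at 54%, a shift in either direction remains possible, and the step from compound 1 to compound 3 is expected to be a modest loss, a number 14 percentage points lower from compound 1 to compound 3 (beyond the scatter), perhaps no larger than the scatter itself. Compound 3 is therefore estimated to give 40% in this assay, with a likely range from 20% to 60%.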

Compound 3, a percentage reported as inhibition, at one concentration (the size of the read-out at that concentration, not a potency): 5%
For compound 3 the middle estimate is 35 percentage points above the measured one; the whole stated range lies above it.
By their numbers in this assay, from the lowest: compound 3; then compounds 2 and 1 (each within the scatter of the next).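

In this assay, the hydroxy on the aromatic carbon, ortho to a carboxy group and para to a large group, proves to be far from a silent feature: hydrogen in its place gives a number 49 percentage points lower from compound 1 to compound 3 (beyond the scatter), a large step. Compounds 1 and 2 both carry this hydroxy and differ only elsewhere, so neither could show what the group contributes, whereas this single change now does so against an otherwise unchanged structure. Nothing available explains why the number falls so far with this change.

Within the data shown here, it remains open whether the hydroxy is the only group that serves at this position, or whether a methoxy, an amine or a fluorine would keep the number near that of compound 1 or share the fate of hydrogen. This is also a single pair, so it cannot be said whether the same change would cost as much on the structure of compound 2, with its different group on the far aromatic ring.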